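This account rests on a few compounds, and the source may have more. Where it says the series, first, only, none or still open, it means among the compounds named here.

Among the compounds with values here, compound 2 `O=C(CCCC1CCN(C(=O)CCC2CCCCC2)CC1)c1ncco1` gives 3 nM in an assay on isolated protein for inhibition of Fatty-acid amide hydrolase 1 (Homo sapiens) (on this read-out lower numbers stand for stronger inhibition and higher numbers for weaker inhibition), the lowest of the two numbers so far; compound 1 `O=C(CCCC1CCN(C(=O)CCc2ccccc2)CC1)c1ncco1` gives 22 nM in this assay. Within the data shown here, the only step measured, a 7.3-fold lower number from compound 1 to compound 2 (0.87 log units; beyond the scatter), shows that the group on the amide carbonyl carbon matters. Compound 3 `CC(C)C(=O)N1CCC(CCCC(=O)c2ncco2)CC1` carries a far larger change there: isopropyl in place of 2-cyclohexylethyl on a carbonyl carbon. Among the measured compounds shown here, no measured step covers such a shortening, so the direction is inferred only from the sensitivity seen in compound 2 with 3 nM. A weaker, higher number is expected for compound 3, about 120 nM in this assay, within 25 nM to 600 nM, a step of a 40-fold higher number from compound 2 to compound 3 (1.60 log units; beyond the scatter).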

Compound 3, half-maximal inhibitory concentration: 250 nM
Compound 3: the middle estimate sits 2.1-fold (0.32 log units) below what was measured; the measured number falls inside the stated range.
By their numbers in this assay, from the lowest: compound 2; then compound 1; then compound 3.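

Replacing the ring-bearing group on the carbonyl carbon with isopropyl moves the number much further than the earlier ring change did: in this assay the series shows an 83-fold higher number from compound 2 to compound 3 (1.92 log units; beyond the scatter), and starting from phenethyl it shows an 11-fold higher number from compound 1 to compound 3 (1.06 log units; beyond the scatter). Both steps are beyond the scatter, so either ring-bearing group gives a lower number than isopropyl, and this position tolerates the loss of the ring and chain poorly. No supporting data explain this loss. The compounds shown leave open whether the ring or the chain length carries the effect. An unbranched hexyl chain on the same carbonyl carbon would separate the two.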